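Swapping a Cyanophenyl for a Difluorophenyl Group

A few compounds are considered here, and "the series" means these few. Any claim that something is new, unique, unknown or untested is made for them only; others in the source may bear on it.

Of the compounds shown here, two have been measured so far in an assay on isolated protein for inhibition of protein deacetylase HDAC6 (Homo sapiens), read by fluorescence, with a stated time of 1 h, tested at 100 nM; a higher number here means more inhibition at the concentration tested (going by the name of the read-out), a lower number less inhibition. Compound 1, `CN(Cc1nc(C2CCN(Cc3ccccc3)CC2)no1)c1ncc(C(=O)NO)cn1`, gives 63% in this assay. Compound 2, `CN(Cc1nc(C2CCN(Cc3ccc(C#N)cc3)CC2)no1)c1ncc(C(=O)NO)cn1`, gives 38% in this assay, the lower of the two numbers. For the measured compounds named here, the only measured step is a number 25 percentage points lower from compound 1 to compound 2 (beyond the scatter), which means that adding the cyano group cost a modest amount of inhibition.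

Compound 3, `CN(Cc1nc(C2CCN(Cc3ccc(F)cc3F)CC2)no1)c1ncc(C(=O)NO)cn1`, has not yet been measured. The change from compound 2 is 2,4-difluorophenyl in place of 4-cyanophenyl on a saturated chain carbon bound to an amine nitrogen in a ring, so the 4-cyanobenzyl group becomes a 2,4-difluorobenzyl group. Going by the values given here, because compound 2 sits a number 25 percentage points lower from compound 1 to compound 2 (beyond the scatter), removing the cyano group might recover some inhibition, but no measured compound shows what two fluorines on that ring do. The estimated step is therefore a number 12 percentage points higher from compound 2 to compound 3 (beyond the scatter), upward but uncertain. Compound 3 is expected to give about 50% in this assay, within a range of 30% to 70%.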

Compound 3, a percentage reported as inhibition, at one concentration (the size of the read-out at that concentration, not a potency): 66%
Estimate against measurement, compound 3: 16 percentage points below; measured number inside the range.
By their numbers in this assay, from the lowest: compound 2; then compounds 1 and 3 (each within the scatter of the next).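

Replacing 4-cyanophenyl with 2,4-difluorophenyl on a saturated chain carbon bound to an amine nitrogen in a ring gives a number 28 percentage points higher from compound 2 to compound 3 (beyond the scatter) in this assay. Measured against plain phenyl at the same place, the difluorinated ring gives a number 3 percentage points higher from compound 1 to compound 3 (within the scatter), so among these compounds a substituted ring at this position does not always go with a lower number; compound 2 is the one that stands apart. Nothing available explains the difference between the nitrile and the two fluorines.

On these data alone, the two fluorines enter together, so what each contributes on its own remains unknown. As far as these compounds go, it also remains open whether a methoxy group or a chlorine on this ring would track compound 2 or compound 3.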